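A few compounds are considered here, and "the series" means these few. Any claim that something is new, unique, unknown or untested is made for them only; others in the source may bear on it.

In a functional assay on HepG2 cells (Homo sapiens) for cytotoxicity, read by MTT assay, with a stated time of 48 h (on this read-out higher numbers stand for weaker inhibition and lower numbers for stronger inhibition), compound 2 `CC(C)=CCC/C(C)=C/CC/C(C)=C/CC[C@@H]1[C@@]2(C)CC/C(=N\OCc3cn(-c4ccc(Cl)cc4)nn3)C(C)(C)[C@@H]2CC[C@@]1(C)O` gives 19900 nM. Compound 3 `CC(C)=CCC/C(C)=C/CC/C(C)=C/CC[C@@H]1[C@@]2(C)CC/C(=N\OCc3cn(-c4cccc(Br)c4)nn3)C(C)(C)[C@@H]2CC[C@@]1(C)O` gives 39800 nM, and a 2.0-fold higher number from compound 2 to compound 3 (0.30 log units; within the scatter) leaves those two unseparated. Compound 1 `COc1cccc(-n2cc(CO/N=C3\CC[C@]4(C)[C@@H](CC/C=C(\C)CC/C=C(\C)CCC=C(C)C)[C@](C)(O)CC[C@H]4C3(C)C)nn2)c1` gives 51300 nM, and a 2.6-fold lower number from compound 1 to compound 2 (0.41 log units; beyond the scatter) sets compound 2 apart from it. Compound 4 `CC(C)=CCC/C(C)=C/CC/C(C)=C/CC[C@@H]1[C@@]2(C)CC/C(=N\OCc3cn(-c4cccc(C(F)(F)F)c4)nn3)C(C)(C)[C@@H]2CC[C@@]1(C)O` carries the change 3-(trifluoromethyl)phenyl in place of 4-chlorophenyl on an aromatic nitrogen. Among the compounds with values here, no measured compound bears trifluoromethyl. Within the data shown here, the closest precedent is a 2.0-fold higher number from compound 2 to compound 3 (0.30 log units; within the scatter), which also removes the 4-chlorophenyl. Alongside it, a 1.3-fold lower number from compound 1 to compound 3 (0.11 log units; within the scatter) shows no separation between the other two aryl groups. A similarly small upward move is therefore expected in this assay, with an estimated 1.8-fold higher number from compound 2 to compound 4 (0.25 log units; within the scatter). For compound 4 the estimated value is 35000 nM, with an expected range of 16000 nM to 75000 nM.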

Compound 4, half-maximal inhibitory concentration: 22700 nM
For compound 4 the middle estimate is 1.5-fold (0.19 log units) above the measured one, within the range that was stated.
By their numbers in this assay, from the lowest: compounds 2, 4, 3 and 1 (each within the scatter of the next, the first and the last beyond it).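

In this assay, 3-(trifluoromethyl)phenyl on the aromatic nitrogen stays unseparated from 4-chlorophenyl (a 1.1-fold higher number from compound 2 to compound 4 (0.06 log units; within the scatter)), and trifluoromethyl stays unseparated from bromo (a 1.8-fold lower number from compound 3 to compound 4 (0.24 log units; within the scatter)). Trifluoromethyl in place of methoxy is separated, though modestly (a 2.3-fold lower number from compound 1 to compound 4 (0.35 log units; beyond the scatter)), so compound 1 now stands apart from both compound 2 and compound 4, but not from compound 3. No available evidence bears on the reason for these steps.

Open, as far as these compounds go, is whether an amine or a carboxylic acid on this aryl group would give a larger step. From the compounds shown here alone, a longer chain in place of the aryl group is equally open.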